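Methoxy on the core: compound 3 to compound 4

The source may hold more compounds than are shown below. What is called first, only, known or untested is meant among the compounds shown, and "the series" means these compounds.

Measured compounds:
compound 1 `COc1ccc2[nH]cc(C(=O)/C(C#N)=C/C=C(\Cl)c3ccc(OC)c(OC)c3)c2c1` gives 34.2%
compound 2 `COc1ccc2[nH]cc(C(=O)/C(C#N)=C/C=C(\Cl)c3ccc(Br)cc3)c2c1` gives 40.8%
compound 3 `COc1ccc(/C(Cl)=C/C=C(\C#N)C(=O)c2c[nH]c3ccccc23)cc1` gives 23.4%

In a functional assay for inhibition, with a stated time of 30 min, tested at 1 mM (a lower number here means less inhibition, a higher number more inhibition at the concentration tested (going by the name of the read-out)), compound 3 stands lowest of the three, with compound 1 nearest and compound 2 furthest, both beyond the scatter. For the measured compounds named here, the one measured step, a number 6.6 percentage points higher from compound 1 to compound 2 (within the scatter), changes the aryl group on the chain and says nothing about the core. Compound 4 `COc1ccc(/C(Cl)=C/C=C(\C#N)C(=O)c2c[nH]c3ccc(OC)cc23)cc1` differs from compound 3 only at the core: methoxy in place of hydrogen on an aromatic carbon. Going by the values given here, no measured pair isolates this change. Compounds 1 and 2 carry the same methoxy on their core and give higher numbers than compound 3, but they also differ from compound 3 in the aryl group on the chain, so that gap cannot be attributed to the methoxy alone. A modest rise is therefore expected, with little confidence; the expected step is a number 8.6 percentage points higher from compound 3 to compound 4 (within the scatter). In this assay compound 4 is estimated at 32%, within 18% to 46%.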

Compound 4, a percentage reported as inhibition, at one concentration (the size of the read-out at that concentration, not a potency): 16.7%
For compound 4 the middle estimate is 15.3 percentage points above the measured one, and the stated range ends above it.
By their numbers in this assay, from the lowest: compounds 4 and 3 (each within the scatter of the next); then compounds 1 and 2 (each within the scatter of the next).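

In this assay methoxy in place of hydrogen on an aromatic carbon of the core gives a number 6.7 percentage points lower from compound 3 to compound 4 (within the scatter) and so shows no change at this position that can be told from the scatter. Compound 1, compound 2 and compound 4 all carry the core methoxy, and the aryl group on the chain is the one place that differs: methoxy in place of bromo on an aromatic carbon gives a number 24.1 percentage points lower from compound 2 to compound 4 (beyond the scatter) while hydrogen in place of methoxy on an aromatic carbon gives a number 17.5 percentage points lower from compound 1 to compound 4 (beyond the scatter) and both steps in this assay lie beyond the scatter. No measurement on hand explains either step.

On these data alone, whether an amine or a carboxylic acid on the same aromatic carbon of the core would give a step beyond the scatter remains open. Also open, as far as these compounds go, is whether the core methoxy gives the same result with 4-bromophenyl on the chain.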